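A few compounds are considered here, and "the series" means these few. Any claim that something is new, unique, unknown or untested is made for them only; others in the source may bear on it.

Compound 2, `O=C(CSc1nnc(-c2ccncc2)o1)N/N=C/c1ccccc1[N+](=O)[O-]`, gives 214000 nM in an ADME assay on NIH3T3 cells (Mus musculus) for cytotoxicity, read by MTT assay, with a stated time of 24 h (a lower number here means a stronger inhibitor, a higher number a weaker inhibitor), the highest of the two numbers recorded, though its neighbour compound 1, `O=C(CSc1nnc(-c2ccncc2)o1)N/N=C/c1ccc(Br)cc1`, gives 169000 nM and the step of a 1.3-fold higher number from compound 1 to compound 2 (0.10 log units; within the scatter) lies within the scatter. Compound 3, `O=C(CSc1nnc(-c2ccncc2)o1)N/N=C/c1ccccc1O`, differs from compound 2 by hydroxy in place of nitro on an aromatic carbon. Going by the values given here, no measured step swaps these two groups; the only step recorded, from compound 1 to compound 2, changes a different group and stayed within the scatter, so no step beyond the scatter is expected here either. Compound 3 is therefore estimated at 200000 nM, between 100000 nM and 400000 nM. That estimate corresponds to an expected step of a 1.1-fold lower number from compound 2 to compound 3 (0.03 log units; within the scatter).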

Compound 3, half-maximal inhibitory concentration: 155000 nM
For compound 3 the middle estimate is 1.3-fold (0.11 log units) above the measured one; the measured number falls inside the stated range.
By their numbers in this assay, from the lowest: compounds 3, 1 and 2 (each within the scatter of the next).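

Putting hydroxy in place of nitro on this aromatic carbon brings in a hydrogen-bond donor, yet this assay shows only a 1.4-fold lower number from compound 2 to compound 3 (0.14 log units; within the scatter) here. The 2-hydroxyphenyl and 4-bromophenyl compounds also stay close, with a 1.1-fold lower number from compound 1 to compound 3 (0.04 log units; within the scatter) in the same measure, so all three aryl groups shown give values within the scatter of one another. Nothing measured here offers an explanation for this flat result. Still open, going by these compounds, is whether an amine or a carboxylic acid on this aromatic carbon would produce a step beyond the scatter.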